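Swapping 2-fluorophenyl for 4-bromophenyl on a shared core

The source may hold more compounds than are shown below. What is called first, only, known or untested is meant among the compounds shown, and "the series" means these compounds.

Compound 1 `Cn1c(-c2ccccc2)cnc1NC(=O)c1ccc(F)cc1`: > 100000 nM (a limit)
Compound 2 `Cn1c(-c2ccccc2F)cnc1NC(=O)c1ccc(F)cc1`: > 100000 nM (a limit)
Compound 3 `Cn1c(-c2ccc(Br)cc2)cnc1NC(=O)c1ccc(F)cc1`: not yet measured

In a toxicity assay on THP-1 cells (Homo sapiens) for inhibition (a higher number here means that more compound is tolerated, a lower number that less compound is tolerated), compound 2 gives > 100000 nM, which is a limit and not a number. Compound 1 offers no firmer anchor, and the whole record is the limit of > 100000 nM in this assay, at which 2 of the 2 values shown sit. Compound 3 carries 4-bromophenyl in place of 2-fluorophenyl on an aromatic carbon of the shared core (4-bromophenyl in place of 2-fluorophenyl on an aromatic carbon). Within the data shown here, the only measured step is a step that the two limits leave unreadable from compound 1 to compound 2, with fluoro in place of hydrogen on an aromatic carbon. Among the measured compounds shown here, it gives no size to carry over, and no measured step involves 4-bromophenyl. Compound 3 is therefore expected to stay near the limit, with a modest fall in this assay possible. The expected step is an at least 1.4-fold lower number from compound 2 to compound 3 (0.15 log units; that floor lies within the scatter). For compound 3 the estimated value is 70000 nM, with an expected range of 20000 nM to 150000 nM.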

Compound 3, half-maximal cytotoxic concentration: 46000 nM
For compound 3 the middle estimate is 1.5-fold (0.18 log units) above the measured one; the measured number falls inside the stated range.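

In this assay this position gives its first readable change: 4-bromophenyl in place of 2-fluorophenyl brings an at least 2.1-fold lower number from compound 2 to compound 3 (0.33 log units; beyond the scatter) on the shared core. Set against the plain phenyl group, the 4-bromophenyl group brings an at least 2.1-fold lower number from compound 1 to compound 3 (0.33 log units; beyond the scatter) and shows that a single halogen on the phenyl group can be enough to lower the tolerated concentration. Both sizes are only floors and the step from compound 1 to compound 2 cannot be read, as only compound 3 has a value that is a number: the limit of > 100000 nM in this assay, at which 2 of the 3 values shown sit.

Whether the fall follows from bromine itself or from its place on the phenyl group stays open, as the compounds shown include neither a 2-bromophenyl nor a 4-fluorophenyl group here. They also leave open how a 4-chlorophenyl or 4-methoxyphenyl group would behave at this position.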